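The source may report more compounds than this note shows. Statements on the series, on what has been measured and on what is new or still open speak of the compounds shown alone.

Measured so far in an ADME assay on MRC5 cells (Homo sapiens) for cytotoxicity, read by neutral red uptake; a lower number here means that less compound is tolerated, a higher number that more compound is tolerated:
Compound 1 `O=c1[nH]c(SCc2ccccc2)nc2ccccc12`: > 64000 nM
Compound 2 `O=c1[nH]c(SCc2cccs2)nc2ccccc12`: > 64000 nM
Compound 3 `O=c1[nH]c(SCc2ccccc2Cl)nc2ccccc12`: > 65000 nM

Compound 2 stands at a limit of this assay, > 64000 nM, and no number is known for it. Across the three compounds the picture is the limit of > 64000 nM in this assay, at which 2 of the 3 values shown sit, and (the limit of > 65000 nM in this assay, at which 1 of the 3 values shown sits). Compound 4 `O=c1[nH]c(SCc2ccc([N+](=O)[O-])s2)nc2ccccc12` has not yet been measured. The change that leads to it is nitro in place of hydrogen on an aromatic carbon. Going by the values given here, two measured steps bear on this. One is a step that the two limits leave unreadable from compound 1 to compound 3, which also places a group on an aromatic carbon. The other is a step that the two limits leave unreadable from compound 1 to compound 2, which introduced the ring that now changes. Among the compounds with values here, neither has a readable size, and no measured step involves nitro. A modest step towards less compound tolerated is nevertheless expected, with a real chance that only a limit is reported again. The expected change is an at least 2.0-fold lower number from compound 2 to compound 4 (0.30 log units; that floor lies within the scatter). For compound 4 the estimate is 32000 nM, with an expected range from 6000 nM to 64000 nM.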

Compound 4, half-maximal cytotoxic concentration: > 64000 nM
Compound 4: no number, only a limit; the forecaster's own chance of this, stated with the estimate: 40%; middle value at least 2.0-fold (0.30 log units) from the limit.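

In this assay, going by these compounds alone, compound 4 gives > 64000 nM, a limit and not a number, and with compound 2 also at a limit, no step between compound 2 and compound 4 can be read. The compounds shown leave open how much of any of the four is tolerated, and whether thiophen-2-yl, chloro or nitro changes that at all.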